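The compounds below may be only part of what the source reports. "The series", "measured", "known", "first", "only" and "open" are said of these compounds alone.

Both compounds measured here share one core and differ only in the group carried on the saturated chain carbon bound to the amide-type nitrogen in the ring. Compound 1 `CC(C)(C)c1ccc(CN2C(=O)S/C(=C\c3ccc(N)cc3)C2=O)cc1` carries a tert-butyl-substituted benzyl group there; in a functional assay on L1210 cells (Mus musculus) for cytotoxicity, read by cell counting, with a stated time of 2 days (a lower number here means a stronger inhibitor, a higher number a weaker inhibitor), compound 1 gives 94000 nM. Compound 2 `Nc1ccc(/C=C2\SC(=O)N(Cc3cccc(F)c3)C2=O)cc1` carries a 3-fluorophenyl on that carbon; in this assay compound 2 gives 100000 nM. Going by the values given here, no step between the two is given beyond the raw numbers, and those numbers cannot be told apart within the usual scatter, so compound 2 stands level with compound 1 rather than apart from it.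

Compound 3 `Nc1ccc(/C=C2\SC(=O)N(Cc3ccc(F)cc3)C2=O)cc1` has not yet been measured. It differs from compound 2 in one place: 4-fluorophenyl in place of 3-fluorophenyl on a saturated chain carbon bound to an amide-type nitrogen in a ring. The fluorine simply moves within the same ring, with nothing added or removed.

Among the compounds with values here, with only two measured compounds and no step recorded, there is no basis for expecting a change beyond the scatter. The step from compound 2 to compound 3 is therefore estimated as no change at the digits printed from compound 2 to compound 3 (within the scatter). Compound 3 is expected to give 100000 nM in this assay, with a range from 50000 nM to 200000 nM.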

Compound 3, half-maximal inhibitory concentration: 24000 nM
The estimate for compound 3 lay 4.2-fold (0.62 log units) above the measured number; the measured number lies below the stated range.
By their numbers in this assay, from the lowest: compound 3; then compounds 1 and 2 (each within the scatter of the next).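

In this assay, the position of the fluorine matters: with the same atoms joined differently, 4-fluorophenyl in place of 3-fluorophenyl on a saturated chain carbon bound to an amide-type nitrogen in a ring gives a 4.2-fold lower number from compound 2 to compound 3 (0.62 log units; beyond the scatter), a change that lies beyond the scatter. The earlier pair could not show this, since the numbers for compound 1 and compound 2 lie within the scatter of each other, and so this site had not yet appeared to respond to any change. Fluoro in place of tert-butyl on an aromatic carbon gives a 3.9-fold lower number from compound 1 to compound 3 (0.59 log units; beyond the scatter), yet compound 2 also carries a fluorine and stays within the scatter of compound 1, so the presence of fluorine alone does not set the number, and nothing available here accounts for the effect of moving it.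

Going by these compounds, whether a chloro group, a methoxy group or an amine in place of the fluorine would follow the same course remains open. On these data alone, it is also open whether a carboxylic acid or a longer chain at this site would lower the number further or raise it.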